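This account rests on a few compounds, and the source may have more. Where it says the series, first, only, none or still open, it means among the compounds named here.

In an in vivo ADME assay on the whole organism for pharmacokinetics, with Canis familiaris (Canis lupus familiaris) as the target (a higher number here means faster removal of the compound, a lower number slower removal), compound 1 `Nc1noc2ccc(-n3nc(C(F)(F)F)c4c3C(=O)N(c3ccc(-c5ccccc5CN5CCCC5)cc3F)CC4)cc12` gives 13.2 mL/min/kg. Compound 2 `CN(C)Cc1ccccc1-c1ccc(N2CCc3c(C(F)(F)F)nn(-c4ccc5onc(N)c5c4)c3C2=O)c(F)c1` gives 17.5 mL/min/kg, which lies within the usual scatter of compound 1. Compound 3 `Nc1noc2ccc(-n3nc(C(F)(F)F)c4c3C(=O)N(c3ccc(-c5ccccc5CN5CC[C@@H](O)C5)cc3F)CC4)cc12` keeps the shared core and differs from compound 2 in one group, on a saturated chain carbon bound to an aromatic carbon: 3-hydroxypyrrolidin-1-yl in place of dimethylamino on a saturated chain carbon bound to an aromatic carbon. For the measured compounds named here, one measured step bears on this, at the same place: dimethylamino replacing pyrrolidin-1-yl gave a 1.3-fold higher number from compound 1 to compound 2 (0.12 log units; within the scatter). Neither measured compound carries the 3-hydroxypyrrolidin-1-yl group, so the range has to stay wide. Even so, the small size of that one step gives no ground to expect a change beyond the scatter in this assay. The estimated step is a 1.3-fold lower number from compound 2 to compound 3 (0.10 log units; within the scatter). Compound 3 is expected to give 14 mL/min/kg, with an estimated range of 7.5 mL/min/kg to 26 mL/min/kg.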

Compound 3, clearance: 5.83 mL/min/kg
Estimate against measurement, compound 3: 2.4-fold (0.38 log units) above; the measured number lies below the stated range.
By their numbers in this assay, from the lowest: compound 3; then compounds 1 and 2 (each within the scatter of the next).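

In this assay this position on a saturated chain carbon bound to an aromatic carbon proves sensitive to the group it carries, since 3-hydroxypyrrolidin-1-yl in place of dimethylamino gives a 3.0-fold lower number from compound 2 to compound 3 (0.48 log units; beyond the scatter) (a modest step). The closer comparison is hydroxy in place of hydrogen on a saturated ring carbon, which gives a 2.3-fold lower number from compound 1 to compound 3 (0.35 log units; beyond the scatter) and is also modest, so this one added group goes with slower removal, whereas the earlier swap between the two amines stayed within the scatter. No measurement shown here explains this slower removal.

The compounds shown leave open whether the mirror-image form of the 3-hydroxypyrrolidin-1-yl group would give a similar number. They also leave open whether a methoxy group on that ring carbon, or a 4-hydroxypiperidin-1-yl group at this position, would do the same.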